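Lengthening the Arm on the Ring Nitrogen

The compounds below may be only part of what the source reports. "The series", "measured", "known", "first", "only" and "open" are said of these compounds alone.

Compound 2 `COC1Cc2c(cnn2-c2ccccc2)C2(CCN(CCCc3ccccc3)CC2)O1` carries a 3-phenylpropyl group on the amine nitrogen in the ring of the shared core. Going by the values given here, in an assay for displacement of a labelled ligand from Sigma non-opioid intracellular receptor 1 (Cavia porcellus), read by scintillation counting, with a stated time of 180 min (a lower number here means a stronger inhibitor, a higher number a weaker inhibitor), compound 2 gives 3.2 nM, the only plain number here. Compound 1 `COC1Cc2c(cnn2-c2ccccc2)C2(CCNCC2)O1`, which has hydrogen on that nitrogen instead, gives only a limit of this assay, > 1000 nM. Going by these compounds, the measured step of an at least 310-fold lower number from compound 1 to compound 2 (2.49 log units; beyond the scatter) shows how much the arm contributes, and it rests on (the limit of > 1000 nM in this assay, at which 1 of the 2 values shown sits), so its true size is unknown. Compound 3 `COC1Cc2c(cnn2-c2ccccc2)C2(CCN(CCCCc3ccccc3)CC2)O1` differs from compound 2 by benzyl in place of phenyl on a saturated chain carbon, three bonds along the chain from an amine nitrogen in a ring, which stretches the arm from 3-phenylpropyl to 4-phenylbutyl while keeping the aromatic ring. Among the compounds with values here, no measured step tests such a lengthening, and the large step from compound 1 speaks only for the arm as a whole. The number expected for compound 3 is 2.5 nM, between 0.8 nM and 8 nM. That estimate means a 1.3-fold lower number from compound 2 to compound 3 (0.11 log units; within the scatter), within the scatter.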

Compound 3, inhibition constant: 3.2 nM
The estimate for compound 3 lay 1.3-fold (0.11 log units) below the measured number, and the stated range covers the measured number.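

In this assay, stretching the arm from 3-phenylpropyl to 4-phenylbutyl gives no change at the digits printed from compound 2 to compound 3 (within the scatter). At this position, then, the longer arm keeps the strong binding of the shorter one, and the two arms cannot be told apart here. Compared with hydrogen on the nitrogen, the longer arm gives an at least 310-fold lower number from compound 1 to compound 3 (2.49 log units; beyond the scatter), a step of the same printed size as the one for the shorter arm, and its true size is unknown, as the value for compound 1 is only a limit: the limit of > 1000 nM in this assay, at which 1 of the 3 values shown sits.

Still open, going by these compounds, is how shorter arms, such as benzyl or phenethyl, or a longer one, such as 5-phenylpentyl, would behave. Also open, on these data alone, is whether a plain butyl chain on the nitrogen, with no aromatic ring, would give a similar number.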